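Swapping the Aryl Group on the Sulfonyl Sulfur

The compounds below may be only part of what the source reports. "The series", "measured", "known", "first", "only" and "open" are said of these compounds alone.

Measured in an assay on cells for inhibition of HSP60/HSP10 (Homo sapiens), with a stated time of 60 min; on this read-out higher numbers stand for weaker inhibition and lower numbers for stronger inhibition:
Compound 1, `O=S(=O)(Nc1ccc2oc(-c3ccccc3)nc2c1)c1ccc(Cl)c(Cl)c1`: > 100000 nM
Compound 2, `O=S(=O)(Nc1ccc2oc(-c3ccc(NS(=O)(=O)c4cccc5nonc45)cc3)nc2c1)c1ccc(Cl)s1`: 13000 nM
Compound 3, `O=S(=O)(Nc1ccc2oc(-c3ccccc3)nc2c1)c1ccc(Cl)c(C(F)(F)F)c1`: > 100000 nM

Compound 1 gives only a limit of this assay, > 100000 nM, not a number. Compound 3 likewise gives only a limit, > 100000 nM. The step that the two limits leave unreadable from compound 1 to compound 3 is therefore unreadable, as the limit of > 100000 nM in this assay, at which 2 of the 3 values shown sit, shows. Compound 2 gives a measured value, 13000 nM.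

Compound 4, `Cc1ccc(S(=O)(=O)Nc2ccc3oc(-c4ccccc4)nc3c2)cc1`, differs from compound 1 by 4-methylphenyl in place of 3,4-dichlorophenyl on a sulfonyl sulfur. Among the compounds with values here, no measured step involves this exchange, and the one measured step between neighbours is unreadable, so no direction can be drawn from the data. Because the limit of > 100000 nM in this assay, at which 2 of the 3 values shown sit, holds compound 1, compound 4 is expected to sit near that same limit. Compound 4 is estimated at 100000 nM, between 30000 nM and 300000 nM. The expected step of a number no higher from compound 1 to compound 4 (the limit leaves the size open) is thus none beyond the scatter.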

Compound 4, half-maximal inhibitory concentration: > 100000 nM
Compound 4: only a limit was reported; the forecaster's own chance of this, stated with the estimate: 75%; the middle value sits exactly at the limit.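

In this assay compound 4 gives only a limit, > 100000 nM, not a number. Within the data shown here, compound 1 also gives only a limit, so no step between compound 1 and compound 4 can be read. The compounds shown leave open how 4-methylphenyl and 3,4-dichlorophenyl compare on a sulfonyl sulfur.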